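Tert-butyl on the Benzoyl Ring of Compound 3

A few compounds are considered here, and "the series" means these few. Any claim that something is new, unique, unknown or untested is made for them only; others in the source may bear on it.

Measured compounds: compound 1 `O=C(Nn1c(-c2cccc([N+](=O)[O-])c2)nc2c(-c3ccc(Cl)cc3)n[nH]c2c1=O)c1ccccc1` gives 18500 nM; compound 2 `O=C(Nn1c(-c2ccccc2)nc2c(-c3ccc(Cl)cc3)n[nH]c2c1=O)c1ccccc1` gives 20600 nM; compound 3 `O=C(Nn1c(CCC2CCCC2)nc2c(-c3ccc(Cl)cc3)n[nH]c2c1=O)c1ccccc1` gives 1800 nM, all in a functional assay on HT-29 cells (Homo sapiens) for inhibition, read by MTT assay, with a stated time of 2 days; a higher number here means a weaker inhibitor of growth, a lower number a stronger inhibitor of growth.

Compound 3 stands lowest of the three numbers in this assay; its nearest neighbour is compound 1 and its furthest is compound 2, both beyond the scatter. Between compound 1 and compound 2 lies a 1.1-fold higher number from compound 1 to compound 2 (0.05 log units; within the scatter), so the nitro group made no difference that can be trusted. The large steps are a 10-fold lower number from compound 1 to compound 3 (1.01 log units; beyond the scatter) and an 11-fold lower number from compound 2 to compound 3 (1.06 log units; beyond the scatter), both from the group on the shared core.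

Compound 4 `CC(C)(C)c1ccc(C(=O)Nn2c(CCC3CCCC3)nc3c(-c4ccc(Cl)cc4)n[nH]c3c2=O)cc1` differs from compound 3 only by tert-butyl in place of hydrogen on an aromatic carbon. Among the compounds with values here, none of the measured steps touches this ring; the three measured compounds all carry the same benzoyl group. There is therefore no comparison on which to expect a step in this assay beyond the scatter, in either direction. Compound 4 is expected to give about 1500 nM, between 500 nM and 5000 nM, which means an expected step of a 1.2-fold lower number from compound 3 to compound 4 (0.08 log units; within the scatter).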

Compound 4, concentration for 50% growth inhibition: 20600 nM
Beside the measured number, compound 4's estimate is 14-fold (1.14 log units) below it; measured number outside the range, above it.
By their numbers in this assay, from the lowest: compound 3; then compounds 1, 2 and 4 (each within the scatter of the next).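

Within the data shown here, the benzoyl ring, the same in all the earlier compounds, now proves to be a position that matters: in this assay, putting tert-butyl on an aromatic carbon para to a large group gives an 11-fold higher number from compound 3 to compound 4 (1.06 log units; beyond the scatter). Among these compounds, the earlier steps showed only that the group on the shared core can move the number, whereas this one shows that a change at the far end of the benzoyl group can also move it by a large amount, here towards weaker inhibition of growth. Nothing available explains why this single added group has so large an effect.

As far as these compounds go, it remains open whether a methyl group or an amine at this same place would raise the number as far. Also open, from the compounds shown here alone, is whether tert-butyl would act in the same way on compound 2, which carries phenyl on the shared core.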